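The source may report more compounds than this note shows. Statements on the series, on what has been measured and on what is new or still open speak of the compounds shown alone.

Measured compounds:
compound 1 `CCNC1=NCCC2(CCCCC2)S1` with 1.38
compound 2 `CNC1=NCCC2(CCCCC2)S1` with 0.88
compound 3 `CCc1ccc(NC2=NCCC3(CCCCC3)S2)cc1` with 2.31

All three were measured in a physicochemical assay for lipophilicity, measured as octanol-water partition, at pH 7.4; on this read-out higher numbers stand for higher lipophilicity and lower numbers for lower lipophilicity. Compound 2 gives 0.88, and compound 1, which differs from it by methyl in place of hydrogen on a saturated chain carbon bound to an amine nitrogen, gives 1.38, so the step of a number 0.50 log units higher from compound 2 to compound 1 (beyond the scatter). Compound 3 stands highest of the three in this assay at 2.31; the difference between its core and the core of compound 2 is not broken down here.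

Compound 4 `CC(C)c1ccc(NC2=NCCC3(CCCCC3)S2)cc1` has not yet been measured. It differs from compound 3 by methyl in place of hydrogen on a saturated chain carbon bound to an aromatic carbon and a saturated chain carbon. Among the compounds with values here, this is the same kind of change as the one from compound 2 to compound 1, but not the same: there the carbon that gains the methyl is bound to an amine nitrogen, here it is bound to an aromatic carbon and a saturated chain carbon. Within the data shown here, the expectation for compound 4 rests on that earlier step, because a number 0.50 log units higher from compound 2 to compound 1 (beyond the scatter) is the only measured example of a methyl added in this way. An expected step of a number 0.44 log units higher from compound 3 to compound 4 (beyond the scatter) is therefore reasonable. Compound 4 is thus estimated at 2.75, expected to fall between 2.4 and 3.1.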

Compound 4, distribution coefficient: 1.57
Compound 4: the middle estimate sits 1.18 log units above what was measured; the whole stated range lies above it.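

Carried to another core, the added methyl changed direction in this assay: the earlier pair shows a number 0.50 log units higher from compound 2 to compound 1 (beyond the scatter) while the new pair shows a number 0.74 log units lower from compound 3 to compound 4 (beyond the scatter) and so the direction of this change did not carry over here. A step read on a carbon bound to an amine nitrogen in one core therefore cannot be assumed for a saturated chain carbon bound to an aromatic carbon and a saturated chain carbon in another core, though one pair on each side sets no rule for the series. Nothing shown here says whether the core, the place of the methyl or something else decides the direction.

The compounds shown leave open whether a tert-butyl, a longer chain or a carboxylic acid in place of the ethyl of compound 3 would also give a lower number. Also open, from the compounds shown here alone, is whether a methyl added on a carbon bound to an amine nitrogen would give a higher number on the core of compound 3.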